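Moving a bromine around the benzyl ring of a piperidine ketone

The source may hold more compounds than are shown below. What is called first, only, known or untested is meant among the compounds shown, and "the series" means these compounds.

Measured compounds:
- compound 1 `O=C(CCCC1CCN(C(=O)c2ccccc2)CC1)c1ncco1`: 77 nM
- compound 2 `O=C(CCCC1CCN(Cc2ccccc2Br)CC1)c1ncco1`: 315 nM

Among the measured compounds shown here, in an assay on isolated protein for inhibition of Fatty-acid amide hydrolase 1 (Homo sapiens) (on this read-out higher numbers stand for weaker inhibition and lower numbers for stronger inhibition), compound 1 gives 77 nM and compound 2 gives 315 nM, the higher of the two numbers measured so far. For the measured compounds named here, the only measured step is a 4.1-fold higher number from compound 1 to compound 2 (0.61 log units; beyond the scatter), which swaps the whole group on the ring nitrogen, benzoyl for 2-bromobenzyl.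

Compound 3 `O=C(CCCC1CCN(Cc2cccc(Br)c2)CC1)c1ncco1` keeps every atom of compound 2 but joins them differently: 3-bromophenyl in place of 2-bromophenyl on a saturated chain carbon bound to an amine nitrogen in a ring. The bromine simply sits at another position of the same ring.

Going by the values given here, no measured step speaks to this kind of change. The step from compound 1 to compound 2 replaced one group by a different one; nothing measured yet compares two positions of the same bromine on an otherwise unchanged benzyl. With no guidance either way, the expected step of a 1.1-fold lower number from compound 2 to compound 3 (0.02 log units; within the scatter) is none beyond the scatter. Compound 3 is therefore estimated at 300 nM in this assay, with a wide range from 90 nM to 1000 nM to reflect that uncertainty.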

Compound 3, half-maximal inhibitory concentration: 10 nM
Estimate against measurement, compound 3: 30-fold (1.48 log units) above; the measured number lies below the stated range.
By their numbers in this assay, from the lowest: compound 3; then compound 1; then compound 2.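

Moving the bromine, with no atom gained or lost, gives a 32-fold lower number from compound 2 to compound 3 (1.50 log units; beyond the scatter) and so means stronger inhibition. On this benzyl ring, the place of the bromine alone can therefore decide much of the result, something the earlier swap of a whole group could not separate out. The comparison with the benzoyl compound also changes: a 7.7-fold lower number from compound 1 to compound 3 (0.89 log units; beyond the scatter) shows stronger inhibition with 3-bromobenzyl on the ring nitrogen, so the weaker result seen earlier with 2-bromobenzyl does not hold for both bromobenzyl groups. Nothing available here explains why the two placements differ so much.

The compounds shown do not reveal whether the bromine itself is needed, since a plain benzyl or a 3-chlorobenzyl group on the same nitrogen would be required to test that. On these data alone, it also remains open whether 3-bromobenzoyl would gain over the unsubstituted benzoyl of compound 1 in the same way, or whether the gain belongs only to the benzyl series.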